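The compounds below may be only part of what the source reports. "The series", "measured", "known", "first", "only" and "open" are said of these compounds alone.

Compound 1 `COc1ccc(Cn2c(=O)n(C3OC(CO)[C@@H](O)[C@H]3O)c3nc(N)nc(O)c32)cc1` sits at the weak end of the series in a functional assay (B cells) with Mus musculus as the target; on this read-out higher numbers stand for an effect only at larger amounts of compound and lower numbers for an effect already at smaller amounts: compound 1 gives 135 uM, the highest of the three numbers measured. Its closest neighbour is compound 2 `Nc1nc(O)c2c(n1)n(C1OC(CO)[C@@H](O)[C@H]1O)c(=O)n2Cc1ccc(OCc2ccccc2)cc1`, which gives 8 uM in this assay; the step of a 17-fold lower number from compound 1 to compound 2 (1.23 log units; beyond the scatter) is large and lies beyond the scatter. Furthest off is compound 3 `C=CCn1c(=O)n(C2OC(CO[Si](C)(C)C(C)(C)C)[C@@H](O)[C@H]2O)c2nc(N)nc(O)c21`, which in this assay gives 1 uM.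

Compound 4 `NC(=O)Cn1c(=O)n(C2OC(CO)[C@@H](O)[C@H]2O)c2nc(N)nc(O)c21` is the next compound to be measured. It differs from compound 1 as follows: carbamoyl in place of 4-methoxyphenyl on a saturated chain carbon bound to an aromatic nitrogen.

Going by the values given here, only one measured step touches this region of the molecule, the step from compound 1 to compound 2, in which a phenyl entered on a saturated chain carbon bound to an oxygen on an aromatic ring and the number fell steeply. That step shows that enlarging this side of the shared core helped; the change to compound 4 goes the other way, since a 4-methoxyphenyl leaves and a much smaller carbamoyl enters. Among the compounds with values here, no measured compound carries a group of this kind at this place, so the direction is uncertain.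

Compound 4 is therefore expected to give 150 uM, within a range from 50 uM to 450 uM. The expected step of a 1.1-fold higher number from compound 1 to compound 4 (0.05 log units; within the scatter) is estimated to stay within the scatter.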

Compound 4, concentration for half-maximal effect: 190 uM
Beside the measured number, compound 4's estimate is 1.3-fold (0.10 log units) below it; the range from low to high includes it.
By their numbers in this assay, from the lowest: compound 3; then compound 2; then compounds 1 and 4 (each within the scatter of the next).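

In this assay, the step to a carbamoyl on the saturated chain carbon bound to an aromatic nitrogen is a 1.4-fold higher number from compound 1 to compound 4 (0.15 log units; within the scatter), so a group with no ring and fewer heavy atoms reads the same as the 4-methoxyphenyl it replaces. Set beside a 17-fold lower number from compound 1 to compound 2 (1.23 log units; beyond the scatter), this shows that the number at this side of the shared core can respond strongly to the group carried, yet the six-membered aromatic ring of compound 1 gives no measurable gain over carbamoyl. Nothing measured here accounts for this result.

The compounds shown leave open whether a carboxylic acid, an amine or a longer chain ending in carbamoyl on the same saturated chain carbon would also stay within the scatter of compound 1, or would shift the number as the phenyl of compound 2 did. They also leave open what lies behind the low number of compound 3, at 1 uM, since compound 3 differs from compound 1 in more than one place, with a tert-butyldimethylsilyl group among the differences.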